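This account rests on a few compounds, and the source may have more. Where it says the series, first, only, none or still open, it means among the compounds named here.

Three compounds share one core and differ only in the group on the ring attached to the sulfonyl. In an ADME assay on microsomes from liver (Homo sapiens) for metabolic stability, tested at 2.5 uM (on this read-out lower numbers stand for slow clearance and higher numbers for fast clearance), compound 1 `COc1cccc(S(=O)(=O)c2cnc3cc(F)ccc3c2-c2cccc(F)c2)c1` gives 3.36 mL/min while compound 2 `N#Cc1cccc(S(=O)(=O)c2cnc3cc(F)ccc3c2-c2cccc(F)c2)c1` gives 0.78 mL/min and compound 3 `O=S(=O)(c1cccc(F)c1)c1cnc2cc(F)ccc2c1-c1cccc(F)c1` gives 0.24 mL/min and so stands lowest of the three. The measured steps are a 4.3-fold lower number from compound 1 to compound 2 (0.63 log units; beyond the scatter) and a 14-fold lower number from compound 1 to compound 3 (1.15 log units; beyond the scatter) and a 3.3-fold lower number from compound 2 to compound 3 (0.51 log units; beyond the scatter) and all of them concern that sulfonyl ring. Compound 4 `O=S(=O)(c1cccc(F)c1)c1cnc2cc(F)ccc2c1-c1ccc(Cl)cc1` differs from compound 3 elsewhere: 4-chlorophenyl in place of 3-fluorophenyl on an aromatic carbon. Going by the values given here, no measured step touches this position, so none bears directly on the change, and the expectation rests on compound 3 alone. The expected step of a 1.3-fold higher number from compound 3 to compound 4 (0.10 log units; within the scatter) in this assay is therefore none beyond the scatter. Compound 4 is expected to give about 0.3 mL/min with a range from 0.1 mL/min to 0.9 mL/min.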

Compound 4, intrinsic clearance in a liver preparation (reported as CLH), per the amount of preparation that the assay uses: 0.98 mL/min
Estimate against measurement, compound 4: 3.3-fold (0.51 log units) below, and the stated range ends below it.
By their numbers in this assay, from the lowest: compound 3; then compounds 2 and 4 (each within the scatter of the next); then compound 1.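

In this assay, 4-chlorophenyl in place of 3-fluorophenyl gives a 4.1-fold higher number from compound 3 to compound 4 (0.61 log units; beyond the scatter), so the number responds to this position on the shared core. Until now, every measured step had concerned only the ring on the sulfonyl. Nothing measured here gives a reason for this step. The change alters both the halogen and its place on the ring, and the compounds shown do not separate the two, leaving open how 4-fluorophenyl or 3-chlorophenyl would read. Also open, as far as these compounds go, is the result with an amine or a carboxylic acid on this ring.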